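Cyclopropyl ether in place of ethyl on the aryl oxygen

The source may report more compounds than this note shows. Statements on the series, on what has been measured and on what is new or still open speak of the compounds shown alone.

Measured compounds in an assay on RPMI-8866 cells for inhibition of integrin alpha-4/beta-1 (Homo sapiens); a higher number here means a weaker inhibitor, a lower number a stronger inhibitor:
compound 1, `O=C(O)CCNC(=O)[C@@H]1CCCN1S(=O)(=O)c1cc(Cl)cc(Cl)c1`, gives 1510 nM
compound 2, `CC(C)(C)Oc1ccc([C@@H](CC(=O)O)NC(=O)[C@@H]2CCCN2S(=O)(=O)c2cc(Cl)cc(Cl)c2)cc1`, gives 0.53 nM
compound 3, `CCOc1ccc([C@@H](CC(=O)O)NC(=O)[C@@H]2CCCN2S(=O)(=O)c2cc(Cl)cc(Cl)c2)cc1`, gives 0.27 nM

Compound 3 has the lowest number of the three; it and compound 2 lie within the scatter of each other, while compound 1 stands far apart, as a 5600-fold lower number from compound 1 to compound 3 (3.75 log units; beyond the scatter) shows. Compound 4, `O=C(O)C[C@@H](NC(=O)[C@@H]1CCCN1S(=O)(=O)c1cc(Cl)cc(Cl)c1)c1ccc(OC2CC2)cc1`, is not yet measured. It differs from compound 3 in one place: cyclopropyl in place of ethyl on an oxygen on an aromatic ring.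

Going by the values given here, only one measured step touches the same place. It is a 2.0-fold lower number from compound 2 to compound 3 (0.29 log units; within the scatter), where a tert-butyl was exchanged for ethyl on the same oxygen, and that step stayed within the scatter. The large steps, a 2800-fold lower number from compound 1 to compound 2 (3.45 log units; beyond the scatter) and a 5600-fold lower number from compound 1 to compound 3 (3.75 log units; beyond the scatter), concern adding the whole aryl group and say nothing about the size of the group on the oxygen. Cyclopropyl is one heavy atom more than ethyl and smaller than tert-butyl, so no step beyond the scatter is expected in this assay, in either direction.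

For compound 4 the estimate is 0.35 nM, with a range from 0.12 nM to 1 nM. This expected step, a 1.3-fold higher number from compound 3 to compound 4 (0.11 log units; within the scatter), stays within the scatter.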

Compound 4, half-maximal inhibitory concentration: 0.85 nM
Estimate against measurement, compound 4: 2.4-fold (0.39 log units) below; the range from low to high includes it.
By their numbers in this assay, from the lowest: compounds 3, 2 and 4 (each within the scatter of the next, the first and the last beyond it); then compound 1.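

In this assay, cyclopropyl in place of ethyl on the oxygen on the aromatic ring gives a 3.1-fold higher number from compound 3 to compound 4 (0.50 log units; beyond the scatter) and is the first change shown at this oxygen to pass beyond the scatter, though only modestly. Cyclopropyl in place of tert-butyl gives a 1.6-fold higher number from compound 2 to compound 4 (0.21 log units; within the scatter) and leaves compound 2 within the scatter of both ethers, so only compound 3 and compound 4 can be told apart among these three. Even so, this change is small beside a 1800-fold lower number from compound 1 to compound 4 (3.25 log units; beyond the scatter) for adding the whole 4-(cyclopropyloxy)phenyl group.

Nothing available here explains the difference between ethyl and cyclopropyl. As far as these compounds go, it also remains open how a longer chain such as n-butyl, or an amine on that chain, would fare on the same oxygen.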